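Thiazole series: chloro replacing dimethylamino at the benzyl ring

The compounds below may be only part of what the source reports. "The series", "measured", "known", "first", "only" and "open" are said of these compounds alone.

Compound 1 `Cc1cc(-c2sc(Cc3cccc(C(F)(F)F)c3)nc2C)ccc1C(N)=O` and compound 2 `Cc1cc(-c2sc(Cc3cccc(N(C)C)c3)nc2C)ccc1C(N)=O` share one core and differ only in the group on the benzylic aromatic ring. In a functional assay on cells for agonist activity at G-protein coupled receptor 52 (Homo sapiens), read by AlphaScreen and cAMP accumulation, with a stated time of 30 min (on this read-out higher numbers stand for an effect only at larger amounts of compound and lower numbers for an effect already at smaller amounts), compound 1 gives 73 nM, and compound 2 gives 690 nM. Going by the values given here, the single measured step, a 9.5-fold higher number from compound 1 to compound 2 (0.98 log units; beyond the scatter), is beyond the scatter, so compound 2 stands as the higher of the two numbers, with compound 1 the nearest point and the lower one.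

Compound 3 `Cc1cc(-c2sc(Cc3cccc(Cl)c3)nc2C)ccc1C(N)=O` is not yet measured. The change from compound 2 is chloro in place of dimethylamino on an aromatic carbon. Among the compounds with values here, the only step that bears on it is the one from compound 1 to compound 2, which is of modest size; compound 3 removes the same dimethylamino group that entered there, and chloro enters in its place. Within the data shown here, since the step of a 9.5-fold higher number from compound 1 to compound 2 (0.98 log units; beyond the scatter) was raised by dimethylamino coming in, the expectation is that taking it out gives a lower number in this assay again, plausibly most of the way back toward compound 1, although chloro is not trifluoromethyl and no step for chloro itself exists here. The expected step is a 5.8-fold lower number from compound 2 to compound 3 (0.76 log units; beyond the scatter). For compound 3 the estimate in this assay is 120 nM, with a range from 40 nM to 400 nM.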

Compound 3, half-maximal effective concentration: 130 nM
For compound 3 the middle estimate is 1.1-fold (0.03 log units) below the measured one; measured number inside the range.
By their numbers in this assay, from the lowest: compounds 1 and 3 (each within the scatter of the next); then compound 2.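

In this assay, a 5.3-fold lower number from compound 2 to compound 3 (0.72 log units; beyond the scatter) shows that the higher number of compound 2 is not tied to the comparison with trifluoromethyl alone, since a second group at this place, chloro, also separates from dimethylamino beyond the scatter. With a 1.8-fold higher number from compound 1 to compound 3 (0.25 log units; within the scatter), chloro and trifluoromethyl cannot be told apart on this aromatic carbon, meta to a large group, even though they differ in their atoms. Among the three groups, dimethylamino alone stands apart, with both of its steps beyond the scatter, but nothing here explains that separation or the match between chloro and trifluoromethyl.

Still open, on these data alone, is whether an unsubstituted carbon at this place, or a small group such as fluoro or methyl, would fall with chloro and trifluoromethyl or with dimethylamino, and whether a primary amine, methoxy or a carboxylic acid would match dimethylamino. Also open, as far as these compounds go, is whether the match between chloro and trifluoromethyl holds on the other carbons of this ring or on a different core.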